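A few compounds are considered here, and "the series" means these few. Any claim that something is new, unique, unknown or untested is made for them only; others in the source may bear on it.

Of the compounds shown here, three have so far been measured in an assay on isolated protein for inhibition of Indoleamine 2,3-dioxygenase 1 (Homo sapiens), read by HPLC, with a stated time of 60 min, in the presence of a further agent that is not named here; a higher number here means a weaker inhibitor, a lower number a stronger inhibitor. Compound 1 `COc1ccccc1Cc1c[nH]c2ccc(Cl)cc12` gives 63000 nM. Compound 2 `CCOc1ccc2[nH]cc(Sc3ccccc3OC)c2c1` reaches only a limit of the assay, > 200000 nM. Compound 3 `COc1cc(OC)cc(Sc2c[nH]c3cc(Cl)ccc23)c1` gives 15000 nM, the lowest of the two numbers; compound 1 sits higher, and that gap lies beyond the usual scatter. Compound 4 `COc1cc(OC)cc(Sc2c[nH]c3c(Cl)c(Cl)ccc23)c1` has not yet been measured. It differs from compound 3 by one change, (chloro in place of hydrogen on an aromatic carbon), that is, chloro in place of hydrogen on an aromatic carbon. Within the data shown here, no measured pair in this assay shows what such an added chloro does, so the size of this step is unknown, and the expectation is a change within or close to the scatter, with no firm direction. Compound 4 is therefore estimated at 12000 nM, between 4000 nM and 40000 nM. That estimate implies an expected step of a 1.3-fold lower number from compound 3 to compound 4 (0.10 log units; within the scatter).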

Compound 4, half-maximal inhibitory concentration: 90000 nM
Compound 4: middle estimate off by 7.5-fold (0.88 log units), on the low side; measured number outside the range, above it.
By their numbers in this assay, from the lowest: compound 3; then compounds 1 and 4 (each within the scatter of the next). At a limit, above all of these: compound 2.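

Among these compounds, this is the first measured pair in this assay to show what an added chloro does: on an aromatic carbon ortho to a chloro group and ortho to a fused ring, it makes a weaker inhibitor, with a 6.0-fold higher number from compound 3 to compound 4 (0.78 log units; beyond the scatter). The step is read between two real numbers, and the only value that is a limit belongs to compound 2: the limit of > 200000 nM in this assay, at which 1 of the 4 values shown sits.

One pair cannot say whether any added group at this carbon would weaken inhibition, or only a chloro. A fluoro or an amine on the same carbon would help to separate these two readings.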